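The source may hold more compounds than are shown below. What is called first, only, known or untested is meant among the compounds shown, and "the series" means these compounds.

Working notes on the series, starting from compound 1 `CC(=O)N(C)CC#CCn1ccnc1`. In a functional assay on the whole organism for antagonist activity, with Mus musculus as the target (a higher number here means that more compound is needed for the effect, a lower number that less compound is needed), compound 1 gives > 100 mg/kg, which is a limit of the assay and not a number. Compound 2 `CC(=O)N(C)CC#CCn1cncc1C` gives > 100 mg/kg, which is likewise only a limit. Among the measured compounds shown here, the one measured step, a step that the two limits leave unreadable from compound 1 to compound 2, therefore has no readable size, and both compounds stand at the limit of > 100 mg/kg in this assay, at which 2 of the 2 values shown sit.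

Compound 3 `COC(=O)N(C)CC#CCn1ccnc1` keeps the core of compound 1 and carries methoxy in place of methyl on a carbonyl carbon, the change from acetyl to methoxycarbonyl: methoxy in place of methyl on a carbonyl carbon. The measured step is a methyl in place of hydrogen on an aromatic carbon, a different change at a different place, so it offers no size or direction to carry over. For the measured compounds named here, no step of definite size or direction can therefore be expected in this assay, and a further limit is the likeliest report. The expected step of a number no higher from compound 1 to compound 3 (the limit leaves the size open) is only a rough estimate. For compound 3 the estimated value is 100 mg/kg, with an expected range from 30 mg/kg to 300 mg/kg.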

Compound 3, dose for half-maximal effect: > 100 mg/kg
Compound 3 gave a limit, no number; the forecaster's own chance of this, stated with the estimate: 70%; the middle value lies on the limit itself.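

In this assay no new step can be read between compound 1 and compound 3, since each gives only a limit and not a number: the limit of > 100 mg/kg in this assay, at which 3 of the 3 values shown sit.

The compounds shown leave open what dose of compound 1, compound 2 or compound 3 gives the half-maximal effect, and whether methoxy in place of methyl on a carbonyl carbon shifts that dose in either direction.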